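The compounds below may be only part of what the source reports. "The series", "measured", "known", "first", "only" and "open" are said of these compounds alone.

Measured so far in this assay, which is a functional assay on A549 cells (Homo sapiens) for antiproliferative activity, read by XTT assay, with a stated time of 24 h; on this read-out higher numbers stand for weaker inhibition and lower numbers for stronger inhibition:

- compound 1 `Cc1ccc(-c2csc(N3N=C(c4ccc(C)s4)CC3c3ccc(F)cc3)n2)cc1` gives > 500 ug/mL, a limit of the assay rather than a number.
- compound 2 `Cc1ccc(C2=NN(c3nc(-c4ccc(F)cc4)cs3)C(c3ccc(F)cc3)C2)s1` gives 125 ug/mL.
- compound 3 `Cc1ccc(-c2csc(N3N=C(c4ccc(Cl)s4)CC3c3ccc(F)cc3)n2)cc1` gives > 500 ug/mL, again only a limit of the assay.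

Compound 2 differs from compound 1 by fluoro in place of methyl on an aromatic carbon, and in this assay this gave an at least 4.0-fold lower number from compound 1 to compound 2 (0.60 log units; beyond the scatter). The core of compound 3 differs from that of compound 1 by chloro in place of methyl on an aromatic carbon; the step that the two limits leave unreadable from compound 1 to compound 3, owing to the limit of > 500 ug/mL in this assay, at which 2 of the 3 values shown sit.

Compound 4 `Fc1ccc(-c2csc(N3N=C(c4ccc(Cl)s4)CC3c3ccc(F)cc3)n2)cc1` carries the same change from compound 3, namely (fluoro in place of methyl on an aromatic carbon), at a place described in the same words as for compound 2. Compound 4 is therefore expected to make a step of an at least 3.3-fold lower number from compound 3 to compound 4 (0.52 log units; beyond the scatter) in this assay, resting on the step of an at least 4.0-fold lower number from compound 1 to compound 2 (0.60 log units; beyond the scatter). Since compound 3 sits only at a limit, the starting point is not a number, so the expectation is loose. Compound 4 is estimated at 150 ug/mL, between 40 ug/mL and 500 ug/mL.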

Compound 4, half-maximal inhibitory concentration: > 500 ug/mL
Compound 4: only a limit was reported (the forecaster's own chance of this, stated with the estimate: 30%); at least 3.3-fold (0.52 log units) between middle value and limit.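

In this assay compound 4 gives > 500 ug/mL, a limit of the assay and not a number. With the 4-fluorophenyl kept, chloro in place of methyl on an aromatic carbon gave an at least 4.0-fold higher number from compound 2 to compound 4 (0.60 log units; beyond the scatter), so the lower number seen for compound 2 does not appear on the chloro-bearing core. This does not show that 4-methylphenyl to 4-fluorophenyl does nothing on that core, as the step between compound 3 and compound 4 cannot be read: the limit of > 500 ug/mL in this assay, at which 3 of the 4 values shown sit.

Left open is whether the lower number seen for compound 2 depends on the methyl it keeps where compound 4 has chloro. Also open, going by these compounds, is whether an amine or a carboxylic acid in place of the fluoro would give a readable number on the core of compound 3.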